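A Second Chloro Group on a Trimethoxy Analogue

The compounds below may be only part of what the source reports. "The series", "measured", "known", "first", "only" and "open" are said of these compounds alone.

Cytotoxicity here is measured in a functional assay on PC-3 cells (Homo sapiens) for cytotoxicity, read by MTT assay; on this read-out lower numbers stand for stronger inhibition and higher numbers for weaker inhibition. Compound 1 `Cc1nc(Nc2ccc(Cl)cc2)sc1C(=O)/C=C/c1ccccc1` gives 24600 nM in this assay. Compound 2 `Cc1nc(Nc2ccc(Cl)c(Cl)c2)sc1C(=O)/C=C/c1ccccc1` differs from it by one change, (chloro in place of hydrogen on an aromatic carbon), and in this assay compound 2 gives 7990 nM. That single change produced a 3.1-fold lower number from compound 1 to compound 2 (0.49 log units; beyond the scatter).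

Compound 3 `COc1cc(/C=C/C(=O)c2sc(Nc3cccc(Cl)c3)nc2C)cc(OC)c1OC` carries a different core, and the difference between its core and the core of compound 1 is not broken down here. In this assay compound 3 reaches only the limit > 25000 nM, which is a limit of the assay and not a number; it is the limit of > 25000 nM in this assay, at which 1 of the 3 values shown sits.

Compound 4 `COc1cc(/C=C/C(=O)c2sc(Nc3ccc(Cl)c(Cl)c3)nc2C)cc(OC)c1OC` is not yet measured. It differs from compound 3 by chloro in place of hydrogen on an aromatic carbon. Among the compounds with values here, this is the same kind of change as the one from compound 1 to compound 2, though the surroundings are not identical: in compound 2 the entering chloro group sits meta to a large group, while in compound 4 it sits para to a large group.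

Within the data shown here, the expectation for compound 4 rests on the single measured step of a 3.1-fold lower number from compound 1 to compound 2 (0.49 log units; beyond the scatter). Applying a step of similar size to compound 3, whose value is only a limit, the expected step is an at least 1.2-fold lower number from compound 3 to compound 4 (0.09 log units; that floor lies within the scatter). On that basis compound 4 is estimated to give about 20000 nM in this assay, with a plausible range from 6000 nM to 60000 nM.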

Compound 4, half-maximal inhibitory concentration: 19300 nM
Beside the measured number, compound 4's estimate is 1.0-fold (0.02 log units) above it; the measured number falls inside the stated range.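

On the core of compound 3, replacing 3-chlorophenyl with 3,4-dichlorophenyl gives an at least 1.2-fold lower number from compound 3 to compound 4 (0.11 log units; that floor lies within the scatter) in this assay. Compound 3 stands at > 25000 nM, which is a limit of the assay and not a number. The result fits the idea that this chloro step carries over from the core of compound 1 to the core of compound 3, but it does not prove that it does, and it does not show that the step keeps its size: the same change on two cores in this assay, a 3.1-fold lower number (0.49 log units; beyond the scatter) from compound 1 to compound 2 and an at least 1.2-fold lower number (0.11 log units; that floor lies within the scatter) from compound 3 to compound 4; the limit leaves it open whether they differ

The compounds shown leave open whether a different group in the same place, such as a fluoro group, an amine or a carboxylic acid, would shift the number in the same way as chloro. Sizing the step on the core of compound 3 would also take a starting compound on that core that gives a true number rather than a limit.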